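The source may report more compounds than this note shows. Statements on the series, on what has been measured and on what is new or still open speak of the compounds shown alone.

In a functional assay on NCI-H358 cells (Homo sapiens) for cytotoxicity, read by sulforhodamine B assay (on this read-out lower numbers stand for an effect already at smaller amounts and higher numbers for an effect only at larger amounts of compound), compound 1 `CCCCCCCCCCCCCCCCCCCCCCCCc1cn([C@@H](CO)[C@H](O)[C@H](O)CCCCCCCCCCCCCC)nn1` gives > 50000 nM. That value is a limit of the assay and not a number, and it is all that is known of compound 1 here. Compound 3 `CCCCCCCCCCCCC/C=C/[C@@H](O)[C@H](CO)n1cc(CCCCCCCCCCCCCCCCCCCCCCCC)nn1` gives > 50000 nM, which is also a limit. The two together make up (the limit of > 50000 nM in this assay, at which 2 of the 3 values shown sit). Among the compounds with values here, the only true number comes from compound 2 `CCCCCCCCCCCCC/C=C/[C@@H](O)[C@H](CO)n1cc(CCC)nn1`, which gives 15700 nM. Within the data shown here, no measured pair differing in one place is available, so the size of a single change cannot be read directly from these data.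

Compound 4 `CCCCCCCCCCCCCC[C@@H](O)[C@@H](O)[C@H](CO)n1cc(CCCCCCCCCCCCC)nn1` has not yet been measured. It differs from compound 1 as follows: hydrogen in place of undecyl on a saturated chain carbon, ten or more bonds along the chain from an aromatic carbon. Among the measured compounds shown here, the one guide to a true number is compound 2 at 15700 nM. A downward move in this assay is therefore expected, of moderate size and with real uncertainty, and the assay may again report only a limit. The expected change is an at least 2.0-fold lower number from compound 1 to compound 4 (0.31 log units; beyond the scatter). For compound 4 the estimated value is 24000 nM, with an expected range from 9000 nM to 50000 nM.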

Compound 4, half-maximal effective concentration: > 50000 nM
Compound 4: only a limit was reported; the forecaster's own chance of this, stated with the estimate: 35%; middle value at least 2.0-fold (0.31 log units) away from the limit.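

In this assay compound 4 gives > 50000 nM, which is a limit of the assay and not a number. Within the data shown here, compound 1 also stands only at a limit, so no step between compound 1 and compound 4 can be read. The compounds shown leave open how far hydrogen in place of undecyl moves the value: the limit of > 50000 nM in this assay, at which 3 of the 4 values shown sit.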